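A new group replaces acetyl, with only a limit to go on

The compounds below may be only part of what the source reports. "The series", "measured", "known", "first", "only" and "open" are said of these compounds alone.

Compound 1 `CC(=O)c1ccccc1OCc1ccc2c(c1)=[N+]([O-])C(C)(C)[N+]=2[O-]` is the starting point, measured in an ADME assay on cells (Erythrocyte, Homo sapiens), read by spectrophotometry and hemolysis, with a stated time of 24 h; a lower number here means a stronger inhibitor, a higher number a weaker inhibitor. In this test compound 1 gives < 50 uM, which is a limit of the assay and not a number. That is the only figure available here: the limit of < 50 uM in this assay, at which 1 of the 3 values shown sits. Two related compounds add no figure to it. Compound 2 `[O-][n+]1onc2ccc(COc3ccc(/C=N/NC(=S)Nc4ccccc4)cc3)cc21` stands at "nd(insoluble)" (no result reported). Compound 3 `CC1(C)[N+]([O-])=c2ccc(COc3ccc(/C=N/NC(N)=S)cc3)cc2=[N+]1[O-]` stands at "nd(insoluble)" (no result reported). Going by the values given here, compound 1 therefore has no exact position, and no step between measured compounds is available to learn from.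

Compound 4 `CC1(C)[N+]([O-])=c2ccc(COc3ccccc3/C=N\NC(=N)N)cc2=[N+]1[O-]` keeps the core of compound 1 and differs in one place, on an aromatic carbon of a six-membered aromatic ring of carbon only, ortho to a large group. There the acetyl leaves and a larger group with no common name enters: a group of 6 heavy atoms (2 carbon, 4 nitrogen; no ring) in place of a group of 3 heavy atoms (2 carbon, 1 oxygen; no ring), on an aromatic carbon.

Among the compounds with values here, compound 1 at < 50 uM is the sole anchor and that value is a limit, so no step beyond the usual scatter is expected in this assay, in either direction. The expected step is a step that the limit leaves unreadable from compound 1 to compound 4. For compound 4 the estimate is 30 uM, with an expected range from 8 uM to 70 uM.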

Compound 4, concentration for 50% inhibition: 114 uM
Estimate against measurement, compound 4: 3.8-fold (0.58 log units) below; the measured number lies above the stated range.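

In this assay, putting the group of 6 heavy atoms (2 carbon, 4 nitrogen; no ring) in place of the acetyl, on an aromatic carbon ortho to a large group, gives an at least 2.2-fold higher number from compound 1 to compound 4 (0.35 log units; beyond the scatter), so this position does respond to a change of group, and here the response is toward a weaker inhibitor. Compound 1 stands at < 50 uM, which is a limit and not a number. The real step could be larger than the one printed, because only a limit anchors its starting end: the limit of < 50 uM in this assay, at which 1 of the 4 values shown sits.

This single replacement alters the size of the group, its atoms and its count of hydrogen-bond donors all at once, so the compounds shown do not say which of these differences matters. They also leave open how a simple amine or a carboxylic acid at the same place would read in this assay, while compound 2 and compound 3 supply no number for comparison.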